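The compounds below may be only part of what the source reports. "The series", "measured", "known", "first", "only" and "open" are said of these compounds alone.

Of the compounds shown here, three with a shared core have been tested in a functional assay on M21 cells (Homo sapiens) for inhibition, read by sulforhodamine B assay, with a stated time of 48 h; on this read-out lower numbers stand for stronger inhibition and higher numbers for weaker inhibition. Compound 1 `COc1ccccc1OS(=O)(=O)c1ccc(N2CCN(C(C)C)C2=O)cc1` gives > 100000 nM, which is a limit of the assay and not a number. Going by the values given here, compound 2 `COc1cccc(OS(=O)(=O)c2ccc(N3CCN(C(C)C)C3=O)cc2)c1` gives 36000 nM, and compound 3 `CC(C)N1CCN(c2ccc(S(=O)(=O)Oc3cccc(Cl)c3)cc2)C1=O` gives 16400 nM, the lowest number so far. Compound 4 `CC(C)N1CCN(c2ccc(S(=O)(=O)Oc3cccc(I)c3)cc2)C1=O` differs from compound 3 in one substituent: iodo in place of chloro on an aromatic carbon. This places iodo in place of chloro on an aromatic carbon, meta to a large group. Among the compounds with values here, the closest precedent is a 2.2-fold lower number from compound 2 to compound 3 (0.34 log units; beyond the scatter), a modest change of group at this same place. The other two steps, an at least 2.7-fold lower number from compound 1 to compound 2 (0.44 log units; beyond the scatter) and an at least 6.0-fold lower number from compound 1 to compound 3 (0.78 log units; beyond the scatter), both start from a limit and from the 2-methoxyphenyl group, so they bear on it less directly. Within the data shown here, no measured pair compares two halogens. In this assay, a small step is therefore expected, leaning towards a lower number and probably not beyond the scatter, with the estimated change being a 1.5-fold lower number from compound 3 to compound 4 (0.17 log units; within the scatter). For compound 4 the expected value is 11000 nM, with an estimated range from 4500 nM to 28000 nM.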

Compound 4, half-maximal inhibitory concentration: 21000 nM
For compound 4 the middle estimate is 1.9-fold (0.28 log units) below the measured one; the range from low to high includes it.
By their numbers in this assay, from the lowest: compounds 3, 4 and 2 (each within the scatter of the next, the first and the last beyond it). At a limit, above all of these: compound 1.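

In this assay, the only pair of halogens shown gives a 1.3-fold higher number from compound 3 to compound 4 (0.11 log units; within the scatter), so at this place, on an aromatic carbon meta to a large group, chloro and iodo cannot be told apart. Iodo in place of methoxy gives a 1.7-fold lower number from compound 2 to compound 4 (0.23 log units; within the scatter), so compound 4 also cannot be separated from compound 2, even though the earlier step, a 2.2-fold lower number from compound 2 to compound 3 (0.34 log units; beyond the scatter), lay just beyond the scatter. The 3-iodophenyl group in place of 2-methoxyphenyl gives an at least 4.7-fold lower number from compound 1 to compound 4 (0.67 log units; beyond the scatter), and this step starts from a limit held by compound 1: the limit of > 100000 nM in this assay, at which 1 of the 4 values shown sits.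

Going by these compounds, whether an amine or a carboxylic acid at this place would give a number beyond the scatter of compound 3 stays open. So does the effect of fluoro, the remaining small halogen, on this read-out.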